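From 2,4-Difluorophenyl to Phenyl: an Unmeasured Analogue

The compounds below may be only part of what the source reports. "The series", "measured", "known", "first", "only" and "open" are said of these compounds alone.

Measured so far:
- Compound 1, `Cc1csc(N)c1C(=O)c1ccc(Cl)cc1`: 1%
- Compound 2, `Cc1sc(N)c(C(=O)c2ccc(Cl)cc2)c1-c1ccccc1`: 1%
- Compound 3, `CC(C)(C)Cc1c(-c2ccc(F)cc2F)sc(N)c1C(=O)c1ccc(Cl)cc1`: 1%

All three compounds were tested in an assay on CHO cells for displacement of a labelled ligand from adenosine receptor A3 (Homo sapiens), read by scintillation counting, tested at 10 uM; a lower number here means less inhibition, a higher number more inhibition at the concentration tested (going by the name of the read-out). In this assay compound 1 gives 1%, compound 2 gives 1% and compound 3 gives 1%. Compound 3 therefore stands level with compounds 1 and 2 at the digits shown: its nearest neighbour is compound 1 and its furthest is compound 2, and in both cases the difference lies within the usual scatter of repeated measurements. None of the three shows appreciable inhibition at the concentration tested.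

Compound 4, `CC(C)(C)Cc1c(-c2ccccc2)sc(N)c1C(=O)c1ccc(Cl)cc1`, has not yet been measured. It differs from compound 3 in one place: phenyl in place of 2,4-difluorophenyl on an aromatic carbon. For the measured compounds named here, no step between measured compounds of this kind is available, so the expectation for compound 4 rests only on the flat picture given by compounds 1, 2 and 3. The change from compound 3 to compound 4 is expected to be a number 1 percentage points higher from compound 3 to compound 4 (within the scatter), that is, no shift beyond the scatter. For compound 4 in this assay the estimated value is 2%, with a range from 0% to 12%.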

Compound 4, a percentage reported as inhibition, at one concentration (the size of the read-out at that concentration, not a potency): 1%
Estimate against measurement, compound 4: 1 percentage points above; the range from low to high includes it.
By their numbers in this assay, from the lowest: compounds 1, 2, 3 and 4 (each within the scatter of the next).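

For the compounds shown here, putting phenyl in place of 2,4-difluorophenyl on the aromatic carbon next to the ring sulfur gives no change at the digits printed from compound 3 to compound 4 (within the scatter) in this assay, the first direct comparison here between two compounds that differ in one place. At this position, then, the two fluorine atoms of compound 3 can go without the read-out moving beyond the scatter. Since compound 3 and compound 4 both show hardly any inhibition at the concentration tested, this comparison cannot tell whether the same swap would matter in a compound with clear inhibition.

Still open, as far as these compounds go, is whether an amine or a carboxylic acid on that phenyl ring, or a longer chain in place of the neopentyl group, would bring any inhibition at all. No other measurement is available that bears on this result.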